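The source may report more compounds than this note shows. Statements on the series, on what has been measured and on what is new or still open speak of the compounds shown alone.

In a functional assay on KB cells (Homo sapiens) for inhibition, read by sulforhodamine B assay (on this read-out lower numbers stand for stronger inhibition of growth and higher numbers for weaker inhibition of growth), compound 3 `Cc1ccc2[nH]c(-c3ccc(-c4ccc(-c5ccccc5)cc4)cc3)nc2c1` gives 32100 nM. Two relatives sit well below it: compound 1 `Cc1ccc2[nH]c(-c3ccc(-c4ccc(-c5cccc(Cl)c5)cc4)cc3)nc2c1` gives 2260 nM and compound 2 `Oc1cccc2[nH]c(-c3ccc(-c4ccc(-c5ccc(OC(F)(F)F)cc5)cc4)cc3)nc12` gives 3310 nM. Compound 3 therefore has the highest number of the three, and its gap to each of the others lies beyond the usual scatter.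

The next compound, compound 4 `Cc1ccc2[nH]c(-c3ccc(-c4ccc(-c5ccc(OC(F)(F)F)cc5)cc4)cc3)nc2c1`, keeps the core of compound 3 and adds one group, with trifluoromethoxy in place of hydrogen on an aromatic carbon, para to a large group: trifluoromethoxy in place of hydrogen on an aromatic carbon.

For the measured compounds named here, only one measured step bears directly on this change. Compound 1 and compound 3 differ by hydrogen in place of chloro on an aromatic carbon, and that step is large: a 14-fold higher number from compound 1 to compound 3 (1.15 log units; beyond the scatter). Read backwards, it shows a substituent on an aromatic carbon going with a much lower number. Compound 2 already carries the 4-(trifluoromethoxy)phenyl piece and sits at 3310 nM, but its core differs from that of compound 3, so it offers only a rough guide.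

A large step towards a lower number is therefore expected, estimated as a 9.2-fold lower number from compound 3 to compound 4 (0.96 log units; beyond the scatter). For compound 4 the estimated value is 3500 nM, with an expected range from 1000 nM to 12000 nM.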

Compound 4, concentration for 50% growth inhibition: 41200 nM
Compound 4: the middle estimate sits 12-fold (1.07 log units) below what was measured; the whole stated range lies below it.
By their numbers in this assay, from the lowest: compounds 1 and 2 (each within the scatter of the next); then compounds 3 and 4 (each within the scatter of the next).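

In this assay, putting trifluoromethoxy on the end phenyl ring, para to a large group, brings no change that can be told apart from scatter, the step being a 1.3-fold higher number from compound 3 to compound 4 (0.11 log units; within the scatter). A substituent on this ring therefore does not lower the number as a general rule, and the low number that goes with the 3-chlorophenyl group stays with that group: swapping it for 4-(trifluoromethoxy)phenyl gives an 18-fold higher number from compound 1 to compound 4 (1.26 log units; beyond the scatter). The 4-(trifluoromethoxy)phenyl piece also goes with a low number only on the core of compound 2, since changing 4-hydroxy-1H-benzimidazol-2-yl to 5-methyl-1H-benzimidazol-2-yl gives a 12-fold higher number from compound 2 to compound 4 (1.10 log units; beyond the scatter), and no measurement at hand explains any of these differences.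

The compounds shown leave open whether the place on the ring or the identity of the group matters more, which a 4-chlorophenyl or a 3-(trifluoromethoxy)phenyl group on the same core could separate. They also leave open how an amine at this place would behave, and whether the core of compound 2 with a plain phenyl end group would already give a low number.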